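The compounds below may be only part of what the source reports. "The series", "measured", "known", "first", "only" and "open" are said of these compounds alone.

Measured compounds:
compound 1 `C=CC(=O)Nc1ccc(-c2nc(Cl)cc(Nc3ccc(C(=O)Nc4ccc(F)cc4)cc3)n2)cc1`: compound 1 gives "not determined" (no result reported) in a functional assay on Raji cells (Homo sapiens) for antiproliferative activity, read by MTT assay, with a stated time of 48 h; a higher number here means a weaker inhibitor, a lower number a stronger inhibitor
compound 2 `C=CC(=O)Nc1ccc(-c2nc(Cl)cc(Nc3ccc(C(=O)N(C)C)cc3)n2)cc1`: compound 2 gives 42900 nM
compound 3 `C=CC(=O)Nc1ccc(-c2nc(Cl)cc(Nc3ccc(C(=O)Nc4cc(C)ccc4C)cc3)n2)cc1`: compound 3 gives 20900 nM

Compound 1 has no number in this assay, so it cannot be placed against compound 2 or compound 3. Compound 4 `C=CC(=O)Nc1ccc(-c2nc(Cl)cc(Nc3ccc(C(=O)N(CC)CC)cc3)n2)cc1` differs from compound 1 in one place: diethylamino in place of (4-fluorophenyl)amino on a carbonyl carbon. Among the measured compounds shown here, the one measured step that bears on this change runs the other way, from a dimethylamino on the carbonyl carbon to an arylamino group: a 2.1-fold lower number from compound 2 to compound 3 (0.31 log units; beyond the scatter). Compound 4 therefore carries the same kind of group as compound 2, and its number in this assay is expected to sit near that of compound 2, with a higher number than an arylamide analogue such as compound 3. The estimate for compound 4 is 45000 nM, within 18000 nM to 110000 nM.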

Compound 4, half-maximal inhibitory concentration: 12500 nM
The estimate for compound 4 lay 3.6-fold (0.56 log units) above the measured number; measured number below the stated range.
By their numbers in this assay, from the lowest: compounds 4 and 3 (each within the scatter of the next); then compound 2.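

In this assay, the size of the alkyl groups on the amide nitrogen matters at this carbonyl carbon: a 3.4-fold lower number from compound 2 to compound 4 (0.54 log units; beyond the scatter). An aryl group and the amide hydrogen are not required to reach the range of compound 3, since diethylamino and (2,5-dimethylphenyl)amino cannot be separated here: a 1.7-fold lower number from compound 3 to compound 4 (0.22 log units; within the scatter). No supporting measurement accounts for either step.

Steps to compound 1 cannot be read, which leaves (4-fluorophenyl)amino unplaced against diethylamino. Open too, from the compounds shown here alone, is how dipropylamino or a cyclic amine such as piperidine or morpholine would read on this carbonyl carbon.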